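Fluoropyridine in Place of a tert-Butyl Pyrazole

A few compounds are considered here, and "the series" means these few. Any claim that something is new, unique, unknown or untested is made for them only; others in the source may bear on it.

Among the compounds with values here, compound 3 `CC(C)(C)n1cc(-c2cc(C(O)(C(F)(F)F)C(F)(F)F)cnc2N2CCN(S(=O)(=O)c3ccc(N)nc3)CC2)cn1` gives 459 mL.min-1.g-1 in an ADME assay (liver) for metabolic stability, with Liver microsome (Rattus norvegicus) as the target, using microsomes and NADPH, with a stated time of 30 min, tested at 1 uM (a lower number here means slower removal, a higher number faster removal of the compound), the highest of the three numbers measured so far; compound 2 `CCn1cc(-c2cc(C(O)(C(F)(F)F)C(F)(F)F)cnc2N2CCN(S(=O)(=O)c3ccc(N)nc3)CC2)cn1` gives 194 mL.min-1.g-1 and compound 1 `Nc1ccc(S(=O)(=O)N2CCN(c3ncc(C(O)(C(F)(F)F)C(F)(F)F)cc3C3CC3)CC2)cn1` gives 27 mL.min-1.g-1. Compound 4 `Nc1ccc(S(=O)(=O)N2CCN(c3ncc(C(O)(C(F)(F)F)C(F)(F)F)cc3-c3cncc(F)c3)CC2)cn1` differs from compound 3 by 5-fluoropyridin-3-yl in place of 1-(tert-butyl)-1H-pyrazol-4-yl on an aromatic carbon. Within the data shown here, two steps bear on this change. The step of a 17-fold higher number from compound 1 to compound 3 (1.23 log units; beyond the scatter) shows how far the whole tert-butyl pyrazole moved the number away from cyclopropyl, with a 7.2-fold higher number from compound 1 to compound 2 (0.86 log units; beyond the scatter) as its smaller counterpart. The step of a 2.4-fold higher number from compound 2 to compound 3 (0.37 log units; beyond the scatter) concerns only the alkyl on the aromatic nitrogen, which compound 4 no longer carries. For compound 4 a step down is therefore expected, a 4.6-fold lower number from compound 3 to compound 4 (0.66 log units; beyond the scatter). Compound 4 is estimated at 100 mL.min-1.g-1, with a range from 40 mL.min-1.g-1 to 280 mL.min-1.g-1.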

Compound 4, intrinsic clearance in microsomes: 19 mL.min-1.g-1
Estimate against measurement, compound 4: 5.3-fold (0.72 log units) above; the measured number lies below the stated range.
By their numbers in this assay, from the lowest: compounds 4 and 1 (each within the scatter of the next); then compound 2; then compound 3.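

In this assay the step of a 24-fold lower number from compound 3 to compound 4 (1.38 log units; beyond the scatter) and the step of a 10-fold lower number from compound 2 to compound 4 (1.01 log units; beyond the scatter) show that an aromatic ring at this position need not bring the high numbers of the two pyrazoles. Replacing cyclopropyl gives a 1.4-fold lower number from compound 1 to compound 4 (0.15 log units; within the scatter) and so leaves compound 4 level with compound 1. Nothing measured here explains why the 5-fluoropyridin-3-yl group and the pyrazoles differ so widely. On these data alone, whether the fluorine or the ring nitrogen goes with the lower number stays open, as does where a phenyl or a pyridin-3-yl without fluorine would stand at this position.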